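The source may report more compounds than this note shows. Statements on the series, on what has been measured and on what is new or still open speak of the compounds shown alone.

Working notes on the urea series.

Of the compounds shown here, three sharing one core have been measured in a functional assay on NCI-H23 cells (Homo sapiens) for inhibition, read by sulforhodamine B assay, with a stated time of 48 h, tested at 100 uM; on this read-out higher numbers stand for a weaker effect at the one concentration tested and lower numbers for a stronger effect. Compound 1 `COc1cc(Cl)cc(-c2nn(-c3cccc(NC(=O)Nc4ccc(Cl)c(C(F)(F)F)c4)c3)cc2-c2ccncc2)c1` gives -50% in this assay. Compound 2 `COc1cc(Cl)cc(-c2nn(-c3cccc(NC(=O)Nc4cc(C(F)(F)F)cc(C(F)(F)F)c4)c3)cc2-c2ccncc2)c1` gives -58% in this assay. Compound 3 `COc1cc(Cl)cc(-c2nn(-c3cccc(NC(=O)Nc4ccc(Cl)c(Cl)c4)c3)cc2-c2ccncc2)c1` gives -20% in this assay, the highest of the three numbers; its gap to compound 1 and to compound 2 is in each case beyond the scatter.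

Compound 4 `COc1cc(Cl)cc(-c2nn(-c3cccc(NC(=O)Nc4cccc(C(F)(F)F)c4)c3)cc2-c2ccncc2)c1` is not yet measured. The change from compound 3 is 3-(trifluoromethyl)phenyl in place of 3,4-dichlorophenyl on an amide-type nitrogen. Going by the values given here, the only measured step that bears on this change is a number 30 percentage points higher from compound 1 to compound 3 (beyond the scatter), where chloro in place of trifluoromethyl raised the number. Compound 4 brings a trifluoromethyl back onto that ring, though as 3-(trifluoromethyl)phenyl without the second halogen that compound 1 carries; compound 2, with two trifluoromethyl groups, sits at the low end of the series. On this basis a step downward, beyond the scatter, is expected for compound 4, roughly a number 20 percentage points lower from compound 3 to compound 4 (beyond the scatter), though smaller than a full return to compound 1 because the change is not the exact reverse of a number 30 percentage points higher from compound 1 to compound 3 (beyond the scatter). Compound 4 is therefore estimated at -40% in this assay, with a range from -65% to -10%.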

Compound 4, a percentage reported as activity, at one concentration (the size of the read-out at that concentration, not a potency): -40%
Beside the measured number, compound 4's estimate shows no gap at the digits printed, and the stated range covers the measured number.
By their numbers in this assay, from the lowest: compounds 2, 1 and 4 (each within the scatter of the next, the first and the last beyond it); then compound 3.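

Placing 3-(trifluoromethyl)phenyl on the amide-type nitrogen in place of 3,4-dichlorophenyl gives a number 20 percentage points lower from compound 3 to compound 4 (beyond the scatter) in this assay, which shows that a low number on this ring does not require a second substituent and that a single trifluoromethyl group is enough to reach it. Against the chloro-bearing ring, hydrogen in place of chloro on an aromatic carbon gives a number 10 percentage points higher from compound 1 to compound 4 (within the scatter), so in this pair the chloro group makes no difference that can be told from the usual scatter. Against the ring with two trifluoromethyl groups, taking away one of the two gives a number 18 percentage points higher from compound 2 to compound 4 (beyond the scatter), so here the second group does count, and the two single removals from the ring do not read alike.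

No measurement at hand accounts for any of these steps. The compounds shown also leave open whether trifluoromethyl itself is needed, since they do not tell how a plain phenyl, a methoxy, a nitrile, an amine or a carboxylic acid on this ring would read at this single concentration.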